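The source may report more compounds than this note shows. Statements on the series, on what has been measured and on what is new or still open speak of the compounds shown alone.

compound 1 `COC(=O)CCCC=C(c1cc(Cl)c(OC)c(C(=O)OC)c1)c1cc(Cl)c(OC)c(C(=O)OC)c1` gives 0.0967 h
compound 2 `COC(=O)CCCC=C(c1cc(C)c(OC)c(C(=O)OC)c1)c1cc(C)c(OC)c(C(=O)OC)c1` gives 0.715 h
compound 3 `COC(=O)CCCC=C(c1cc(C#N)c(OC)c(C(=O)OC)c1)c1cc(C#N)c(OC)c(C(=O)OC)c1` gives 0.207 h

In an ADME assay on the whole organism (plasma) for metabolic stability, with Rattus norvegicus as the target (a lower number here means that the compound disappears faster, a higher number that the compound lasts longer), compound 1 stands lowest of the three, and its gaps up to compound 3 and compound 2 both lie beyond the scatter. Compound 4 `C#CCCCC=C(c1cc(Cl)c(OC)c(C(=O)OC)c1)c1cc(Cl)c(OC)c(C(=O)OC)c1` has not yet been measured. It carries ethynyl in place of methoxycarbonyl on a saturated chain carbon, three bonds along the chain from a double-bonded chain carbon and otherwise matches compound 1. Among the measured compounds shown here, no measured pair shows this change, so the forecast is uncertain. The step of a 3.1-fold higher number from compound 1 to compound 4 (0.49 log units; beyond the scatter) is expected to be a moderate rise beyond the scatter. Compound 4 is estimated at 0.3 h with an expected range from 0.1 h to 1 h for its half-life.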

Compound 4, half-life: 0.343 h
For compound 4 the middle estimate is 1.1-fold (0.06 log units) below the measured one, and the stated range covers the measured number.
By their numbers in this assay, from the lowest: compound 1; then compounds 3 and 4 (each within the scatter of the next); then compound 2.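

The earlier compounds shown here differed only on the shared core, whereas compound 4 shows that the chain end also matters in this assay: ethynyl in place of methoxycarbonyl, with the rest of compound 1 unchanged, gives a 3.5-fold higher number from compound 1 to compound 4 (0.55 log units; beyond the scatter). The chain methoxycarbonyl is thus not needed for this longer half-life. Nothing available explains the step.

Going by these compounds, it remains open whether a carboxylic acid, an amine or a longer chain at this place would shift the half-life similarly. On these data alone, whether the step would hold on the cores of compound 2 and compound 3 also remains open.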